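The compounds below may be only part of what the source reports. "The series", "measured", "known", "first", "only" and "open" are said of these compounds alone.

In a functional assay on HepG2 cells (Homo sapiens) for antiproliferative activity, read by MTT assay, with a stated time of 72 h (on this read-out lower numbers stand for stronger inhibition and higher numbers for weaker inhibition), the measured compounds are:
compound 1 `O=C(N/N=C/c1ccc([N+](=O)[O-])cc1)Nc1ccc(Oc2ccnc3[nH]ccc23)c(F)c1` with 3030 nM
compound 2 `O=C(N/N=C/c1ccc(F)cc1Cl)Nc1ccc(Oc2ccnc3[nH]ccc23)c(F)c1` with 1110 nM
compound 3 `COc1ccc(/C=N/NC(=O)Nc2ccc(Oc3ccnc4[nH]ccc34)c(F)c2)cc1` with 1770 nM

Compound 3 sits within the scatter of the other two values (a 1.7-fold lower number from compound 1 to compound 3 (0.23 log units; within the scatter); a 1.6-fold higher number from compound 2 to compound 3 (0.20 log units; within the scatter)). Compound 4 `O=C(N/N=C/c1ccc(O)cc1O)Nc1ccc(Oc2ccnc3[nH]ccc23)c(F)c1` carries 2,4-dihydroxyphenyl in place of 4-methoxyphenyl on a carbon with a double bond to nitrogen. Within the data shown here, no measured compound carries this group, so the evidence is indirect. The three measured steps all change this same substituted phenyl, and the largest is modest (a 2.7-fold lower number from compound 1 to compound 2 (0.44 log units; beyond the scatter)). A step beyond the scatter is therefore not expected, in either direction. The expected step is small (a 1.0-fold lower number from compound 3 to compound 4 (0.02 log units; within the scatter)). For compound 4 the estimated value is 1700 nM, with an expected range from 600 nM to 4800 nM.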

Compound 4, half-maximal inhibitory concentration: 4550 nM
Estimate against measurement, compound 4: 2.7-fold (0.43 log units) below; measured number inside the range.
By their numbers in this assay, from the lowest: compounds 2, 3, 1 and 4 (each within the scatter of the next, the first and the last beyond it).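

In this assay, 2,4-dihydroxyphenyl on the carbon with a double bond to nitrogen gives the first step from 4-methoxyphenyl that lies beyond the scatter (a 2.6-fold higher number from compound 3 to compound 4 (0.41 log units; beyond the scatter)), and the largest step in the set comes against 2-chloro-4-fluorophenyl (a 4.1-fold higher number from compound 2 to compound 4 (0.61 log units; beyond the scatter)). Against 4-nitrophenyl the step stays within the scatter (a 1.5-fold higher number from compound 1 to compound 4 (0.18 log units; within the scatter)), so this position tolerates quite different substituted phenyls with only modest shifts. Nothing available here explains these differences. The compounds shown leave open whether a single hydroxy group, an amine or a carboxylic acid on this phenyl would give a value like that of compound 4.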